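The source may report more compounds than this note shows. Statements on the series, on what has been measured and on what is new or still open speak of the compounds shown alone.

Measured compounds:
Compound 1 `COc1cc(NC(C)CCCNC(=O)NNC(=O)Nc2cc(C(F)(F)F)cc(C(F)(F)F)c2)c2ncccc2c1`: 16000 nM
Compound 2 `COc1cc(NC(C)CCCNC(=O)Nc2ccc(C(F)(F)F)cc2)c2ncccc2c1`: 22000 nM

In a functional assay on SW-620 cells (Homo sapiens) for inhibition, read by MTT assay, with a stated time of 72 h (a lower number here means a stronger inhibitor, a higher number a weaker inhibitor), compound 1 gives 16000 nM, and compound 2 gives 22000 nM. On the numbers shown compound 2 stands at the top, but its distance to compound 1 lies within the scatter, so no real difference between them is established. Compound 3 `COc1cc(NC(C)CCCNC(=O)Nc2cccc(Cl)c2)c2ncccc2c1` has not been measured; it differs from compound 2 in one place: 3-chlorophenyl in place of 4-(trifluoromethyl)phenyl on an amide-type nitrogen. Among the compounds with values here, no measured pair shows such a change, so no step beyond the scatter is expected in this assay in either direction. The step expected is a 1.1-fold lower number from compound 2 to compound 3 (0.04 log units; within the scatter). For compound 3 the estimate is 20000 nM, between 7000 nM and 55000 nM.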

Compound 3, half-maximal inhibitory concentration: 26000 nM
Compound 3: middle estimate off by 1.3-fold (0.11 log units), on the low side, within the range that was stated.
By their numbers in this assay, from the lowest: compounds 1, 2 and 3 (each within the scatter of the next).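

Within the data shown here, compound 2 and compound 3 give the first comparison that differs in only one place. Replacing 4-(trifluoromethyl)phenyl with 3-chlorophenyl on the amide-type nitrogen gives, in this assay, a 1.2-fold higher number from compound 2 to compound 3 (0.07 log units; within the scatter) so this exchange, from a group of 10 heavy atoms to one of 7, produces no measurable difference. No measurement is available that bears on why the two groups read alike. Still open, as far as these compounds go, is whether an unsubstituted phenyl, a carboxylic acid or an amine on this nitrogen would give a step beyond the scatter.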